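Thiourea series: lipophilicity on swapping the aryl group

The compounds below may be only part of what the source reports. "The series", "measured", "known", "first", "only" and "open" are said of these compounds alone.

Measured so far:
compound 1 `O=C(NC(=S)Nc1ccccc1Cl)Nc1ccc2c(c1)C(=O)C(=O)N2Cc1ccccc1`: 3.01
compound 2 `Cc1cccc(NC(=S)NC(=O)Nc2ccc3c(c2)C(=O)C(=O)N3Cc2ccccc2)c1`: 2.92
compound 3 `O=C(NC(=S)Nc1ccccc1Cl)Nc1ccc2c(c1)C(=O)C(=O)N2Cc1ccccc1Cl`: 3.98

In a physicochemical assay for lipophilicity, in phosphate buffer, measured as octanol-water partition (on this read-out lower numbers stand for lower lipophilicity and higher numbers for higher lipophilicity), compound 3 stands highest of the three numbers; the nearest measured value belongs to compound 1, the furthest to compound 2, and both gaps lie beyond the scatter, as the step of a number 0.97 log units higher from compound 1 to compound 3 (beyond the scatter) shows. Compound 4 `Cc1cccc(NC(=S)NC(=O)Nc2ccc3c(c2)C(=O)C(=O)N3Cc2ccccc2Cl)c1` awaits measurement. The change is 3-methylphenyl in place of 2-chlorophenyl on an amide-type nitrogen. For the measured compounds named here, one measured step bears directly on it, the same exchange made on the other pair: a number 0.09 log units lower from compound 1 to compound 2 (within the scatter), a difference within the scatter. On that basis the expected step of a number 0.08 log units lower from compound 3 to compound 4 (within the scatter) is none beyond the scatter. Compound 4 is therefore expected to give about 3.9, with a range from 3.5 to 4.3.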

Compound 4, partition coefficient: 3.72
Beside the measured number, compound 4's estimate is 0.18 log units above it, within the range that was stated.
By their numbers in this assay, from the lowest: compounds 2 and 1 (each within the scatter of the next); then compounds 4 and 3 (each within the scatter of the next).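

In this assay, the exchange of 2-chlorophenyl for 3-methylphenyl on the amide-type nitrogen now reads on a second pair (a number 0.26 log units lower from compound 3 to compound 4 (within the scatter)), and it stays within the scatter there as on the first pair (a number 0.09 log units lower from compound 1 to compound 2 (within the scatter)). Chloro in place of hydrogen on an aromatic carbon also repeats beyond the scatter with 3-methylphenyl at that nitrogen (a number 0.80 log units higher from compound 2 to compound 4 (beyond the scatter)), as it did with 2-chlorophenyl (a number 0.97 log units higher from compound 1 to compound 3 (beyond the scatter)). No measurement available explains the size of either step.

As far as these compounds go, the effect at this nitrogen of an aryl group carrying an amine or a carboxylic acid remains open.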